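Chain Length and Inhibition in Three Measured Compounds

This account rests on a few compounds, and the source may have more. Where it says the series, first, only, none or still open, it means among the compounds named here.

Measured in a functional assay on the whole organism with Rattus norvegicus as the target, at a dose of 100 mg/kg; a higher number here means more inhibition at the dose given (going by the name of the read-out), a lower number less inhibition:
Compound 1, `C/N=C(/NC#N)NCCCCn1nc(-c2ccccc2)c(C)cc1=O`, gives 46.4%.
Compound 2, `C/N=C(/NC#N)NCCCCCn1nc(-c2ccccc2)cc(C)c1=O`, gives 33.8%.
Compound 3, `C/N=C(/NC#N)NCCCCn1nc(-c2ccccc2)cc(C)c1=O`, gives 68.6%.

Compounds 2 and 3 share a core and differ only by a group of 7 heavy atoms (3 carbon, 4 nitrogen; no ring) in place of a group of 8 heavy atoms (4 carbon, 4 nitrogen; no ring), on a saturated chain carbon, four bonds along the chain from an aromatic nitrogen. This change brought a number 34.8 percentage points higher from compound 2 to compound 3 (beyond the scatter). Compound 1 and compound 2 differ in their cores, and that difference is not broken down here. Compound 4, `C/N=C(/NC#N)NCCCn1nc(-c2ccccc2)c(C)cc1=O`, is not yet measured; it arises from compound 1 by a group of 7 heavy atoms (3 carbon, 4 nitrogen; no ring) in place of a group of 8 heavy atoms (4 carbon, 4 nitrogen; no ring), on a saturated chain carbon, three bonds along the chain from an aromatic nitrogen. This is the same kind of change as from compound 2 to compound 3, but not the same: there the place was four bonds along the chain from an aromatic nitrogen, here it is three bonds. Among the compounds with values here, because only the step of a number 34.8 percentage points higher from compound 2 to compound 3 (beyond the scatter) is known and the core and place differ, a smaller rise is expected here, a number 9.6 percentage points higher from compound 1 to compound 4 (within the scatter). For compound 4 the estimate in this assay is 56%, between 32% and 80%.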

Compound 4, a percentage reported as inhibition, in the whole organism at one dose (the size of the read-out at that dose, not a potency): 17.2%
Estimate against measurement, compound 4: 38.8 percentage points above, outside the stated range (below it).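

In this assay, the same swap at a new place on the chain gives a number 29.2 percentage points lower from compound 1 to compound 4 (beyond the scatter). Set beside the earlier step, this shows that the change does not carry over from one core to the other, since its direction reverses: the same change on two cores in this assay, a number 34.8 percentage points higher (beyond the scatter) from compound 2 to compound 3 and a number 29.2 percentage points lower (beyond the scatter) from compound 1 to compound 4, 64 percentage points apart, beyond the scatter of two such steps It does not show what lies behind the reversal, since the two steps differ both in core and in place, four bonds along the chain from an aromatic nitrogen in one and three bonds in the other, and two steps cannot separate these.

The compounds shown leave open how a longer chain would behave on the core of compound 1. They also leave open what a shorter chain, or an amine at the chain end, would do on the core of compound 3.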